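The source may hold more compounds than are shown below. What is called first, only, known or untested is meant among the compounds shown, and "the series" means these compounds.

Measured in an ADME assay on L1210/0 cells (Mus musculus) for cytotoxicity, with a stated time of 48 h (on this read-out higher numbers stand for weaker inhibition and lower numbers for stronger inhibition), both values being limits:
- compound 1 `O=c1[nH]c(=O)n([C@H]2C[C@H](O)[C@@H](CO)O2)cc1C#CCCCO`: > 200000 nM
- compound 2 `CS(=O)(=O)Cc1cn([C@H]2C[C@H](O)[C@@H](CO)O2)c(=O)[nH]c1=O`: > 200000 nM

Compound 2 gives only a limit, > 200000 nM. For the measured compounds named here, the one other value shown is also a limit, so the series has no number yet: the limit of > 200000 nM in this assay, at which 2 of the 2 values shown sit.

The next change gives compound 3 `O=c1[nH]c(=O)n([C@H]2C[C@H](O)[C@@H](CO)O2)cc1/C=C/Cl`, with 2-chloroethenyl in place of (methylsulfonyl)methyl on an aromatic carbon.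

Going by the values given here, the only measured step, a step that the two limits leave unreadable from compound 1 to compound 2, has no readable size and gives no scale to carry over. In this assay, any readable result would have to lie on the stronger-inhibition side of the limit, but the reading may well stay at the limit. The expected change is modest and poorly supported: an at least 1.3-fold lower number from compound 2 to compound 3 (0.12 log units; that floor lies within the scatter). For compound 3 the estimated value is 150000 nM, with an expected range of 40000 nM to 400000 nM.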

Compound 3, half-maximal inhibitory concentration: > 200000 nM
Compound 3 was reported as a limit (the forecaster's own chance of this, stated with the estimate: 55%); at least 1.3-fold (0.12 log units) between middle value and limit.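

Compound 3 comes back as a limit, like compound 1 and compound 2, so no step among these three compounds can be read in this assay. Whether any group at this place on the shared core would give a readable number remains open, with the series so far resting on: the limit of > 200000 nM in this assay, at which 3 of the 3 values shown sit.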